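A few compounds are considered here, and "the series" means these few. Any claim that something is new, unique, unknown or untested is made for them only; others in the source may bear on it.

Measured so far in a functional assay on A2780 ADR cells (Homo sapiens) for cytotoxicity, read by MTT assay, with a stated time of 24 h; a higher number here means a weaker inhibitor, a lower number a stronger inhibitor:

compound 1, `CCCCC[C@@H](CCC[C@H]1CC=CC(=O)O1)OC`, 9000 nM
compound 2, `CCCCC[C@H](CCC[C@@H]1CC=CC(=O)O1)OC`, 20500 nM
compound 3, `CCCCC[C@H](C[C@H](O)C[C@H]1CC=CC(=O)O1)OC`, 57500 nM

Compound 3 gives the highest number of the three in this assay: compound 2 is nearest and compound 1 furthest, both with lower numbers, and both gaps lie beyond the scatter.

The next compound, compound 4, is `CCCCC[C@@H](C[C@@H](O)C[C@@H]1CC=CC(=O)O1)OC`. Against compound 3 the change is the two compounds have the same atoms and bonds and differ only in configuration as drawn: 3 of 3 stereo elements differ (all stereocentres are inverted: mirror images); a stereocentre at a saturated chain carbon is drawn R in compound 3 and S in compound 4; a stereocentre at a saturated chain carbon is drawn S in compound 3 and R in compound 4; a stereocentre at a saturated ring carbon is drawn R in compound 3 and S in compound 4.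

Among the measured compounds shown here, the only measured step that speaks to a full inversion of configuration is a 2.3-fold higher number from compound 1 to compound 2 (0.36 log units; beyond the scatter), and that step can be laid to the fact that compounds 1 and 2 differ only in the configuration as drawn. In that pair the compound whose chain stereocentre and ring stereocentre are both drawn S, compound 1, gave the lower number. Compound 4 carries the S configuration at both of those positions, as compound 1 does, while compound 3 carries them as R, as compound 2 does. For the measured compounds named here, on the strength of that single pair, a modest step toward a lower number in this assay is expected for compound 4, of about the size seen in the pair, though the extra stereocentre bearing the hydroxyl in compound 3 and compound 4 has no measured counterpart and widens the uncertainty.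

The estimate for compound 4 in this assay is therefore 28000 nM, within 11000 nM to 75000 nM, which means an expected step of a 2.1-fold lower number from compound 3 to compound 4 (0.31 log units; beyond the scatter).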

Compound 4, half-maximal inhibitory concentration: 46300 nM
Beside the measured number, compound 4's estimate is 1.7-fold (0.22 log units) below it; the range from low to high includes it.
By their numbers in this assay, from the lowest: compound 1; then compound 2; then compounds 4 and 3 (each within the scatter of the next).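

In this assay, inverting all three stereocentres of the hydroxyl-bearing pair gives a 1.2-fold lower number from compound 3 to compound 4 (0.09 log units; within the scatter), so this pair of mirror images shows no separation that can be read, and the hydroxyl-bearing compounds give no sign of a preferred hand: the fact that compounds 3 and 4 differ only in the configuration as drawn

The pair without the hydroxyl gave a 2.3-fold higher number from compound 1 to compound 2 (0.36 log units; beyond the scatter), a step beyond the scatter, so the same kind of change, full inversion, is beyond the scatter in one pair and within it in the other: the fact that compounds 1 and 2 differ only in the configuration as drawn

Any rule that the S configuration at the chain and ring stereocentres gives the lower number therefore rests on compounds 1 and 2 alone, and compounds 3 and 4 go against it.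

Still open is how this assay would read a compound with only the stereocentre bearing the hydroxyl inverted and the other two kept, as no such partial change stands among these compounds. Also open, going by these compounds, is whether an amine in place of the hydroxyl, or a longer chain at the end of the side chain, would make configuration matter in this assay.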